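The compounds below may be only part of what the source reports. "The series", "measured", "known", "first", "only" and "open" are said of these compounds alone.

For the measured compounds named here, compound 1 `O=C(NNc1cccc(Cl)c1)c1cccc(NS(=O)(=O)c2cnc(O)nc2O)c1` is the only compound here with a numbered result: in a functional assay on SGC-7901 cells (Homo sapiens) for antiproliferative activity, read by MTT assay, with a stated time of 24 h (on this read-out higher numbers stand for weaker inhibition and lower numbers for stronger inhibition), compound 1 gives 11800 nM. Compound 2 `Cc1ccc(C(=O)NNC(=O)c2ccc(NS(=O)(=O)c3cnc(O)nc3O)cc2)cc1` in this assay gives > 20000 nM, which is a limit of the assay and not a number, so that one of the two values sits at the limit of > 20000 nM in this assay, at which 1 of the 2 values shown sits. Compound 3 `O=C(NNC(=O)c1cccc(NS(=O)(=O)c2cnc(O)nc2O)c1)c1ccc(F)cc1` has not been measured. It differs from compound 1 by (4-fluorophenyl)carbonyl in place of 3-chlorophenyl on an amine nitrogen. Going by the values given here, no step between measured compounds is available, so the expectation is tentative. Compound 3 is expected to sit near compound 1 or somewhat weaker, with an estimated step of a 1.4-fold higher number from compound 1 to compound 3 (0.16 log units; within the scatter). In this assay compound 3 is expected to give about 17000 nM, between 8000 nM and 40000 nM.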

Compound 3, half-maximal inhibitory concentration: > 20000 nM
Compound 3: no number, only a limit (the forecaster's own chance of this, stated with the estimate: 45%); middle value at least 1.1-fold (0.07 log units) away from the limit.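

On this amine nitrogen, (4-fluorophenyl)carbonyl in place of 3-chlorophenyl gives in this assay an at least 1.6-fold higher number from compound 1 to compound 3 (0.22 log units; that floor lies within the scatter) and so brings no gain, though it does not establish a loss. Compound 3 has a limit of the assay and not a number, which leaves only a floor for this step: the limit of > 20000 nM in this assay, at which 2 of the 3 values shown sit. Going by these compounds, what an acetyl or a benzyl group on this nitrogen would give remains open. So does how an unsubstituted phenyl compares with 3-chlorophenyl.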